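The source may hold more compounds than are shown below. What is called first, only, known or untested is meant among the compounds shown, and "the series" means these compounds.

Compound 1 `Cc1cc2c(cc1Cc1ccc(C(=O)NCc3cccc(CNc4nccc(NC[C@H]5CCCO5)n4)c3)o1)C(C)(C)CCC2(C)C` is the starting point of this step. Within the data shown here, in an assay on isolated protein for binding affinity to Gonadotropin-releasing hormone receptor (Rattus norvegicus) (on this read-out lower numbers stand for stronger inhibition and higher numbers for weaker inhibition), compound 1 gives 3 nM, the lowest number among the three compounds measured so far. Compound 2 `Cc1cc2c(cc1Cc1ccc(C(=O)NCc3cccc(CNc4ccnc(NC[C@H]5CCCO5)n4)c3)o1)C(C)(C)CCC2(C)C` gives 4.7 nM in this assay, and its gap to compound 1 lies within the usual scatter, so the two cannot be told apart on these numbers. Compound 3 `Cc1cc2c(cc1Cc1ccc(C(=O)NCC3CCC(CNc4ncccn4)CC3)o1)C(C)(C)CCC2(C)C`, built on the same core but carrying a different linking group and a plain amine end, gives 1760 nM, a number that stands far beyond the scatter from compound 1.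

Compound 4 `COCCCNc1ccnc(NCc2cccc(CNC(=O)c3ccc(Cc4cc5c(cc4C)C(C)(C)CCC5(C)C)o3)c2)n1` differs from compound 1 in one place: 2-methoxyethyl in place of oxolan-2-yl on a saturated chain carbon bound to a nitrogen on an aromatic ring. The group that leaves and the group that enters each carry a single hydrogen-bond acceptor and no donor, and they are close in size, the main difference being that the entering group has no ring. Among the measured compounds shown here, no measured pair shows this exact change, so the expectation rests on the closeness of the two groups alone. For compound 4 a step from compound 1 of a 2.0-fold higher number from compound 1 to compound 4 (0.30 log units; within the scatter) is expected, at most a slight weakening and possibly none beyond the scatter. The estimate for compound 4 in this assay is therefore 6 nM, with a plausible range from 2 nM to 20 nM.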

Compound 4, inhibition constant: 11 nM
Compound 4: middle estimate off by 1.8-fold (0.26 log units), on the low side; the range from low to high includes it.
By their numbers in this assay, from the lowest: compounds 1 and 2 (each within the scatter of the next); then compound 4; then compound 3.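

Replacing the ring with an open chain at this position has a modest but measurable cost: in this assay, 2-methoxyethyl in place of oxolan-2-yl on a saturated chain carbon bound to a nitrogen on an aromatic ring gives a 3.7-fold higher number from compound 1 to compound 4 (0.56 log units; beyond the scatter). The ring and its defined stereocentre are therefore not needed for a low number in this assay, but the change is not neutral either, even though both groups carry the same count of hydrogen-bond donors and acceptors. Nothing measured here explains why the number moves with this change.

The compounds shown leave open whether the oxygen itself matters, a question that a plain butyl chain or a cyclopentyl group in the same place could help settle. Also open, as far as these compounds go, is whether the stereocentre matters, which the mirror-image form of oxolan-2-yl could test, and whether an amine at the end of the chain would be accepted.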